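The source may hold more compounds than are shown below. What is called first, only, known or untested is meant among the compounds shown, and "the series" means these compounds.

Working notes on the series. Two compounds have numbers in an in vitro assay on BaF3 cells for displacement of a labelled ligand from C-X-C chemokine receptor type 3 (Homo sapiens); a higher number here means a weaker inhibitor, a lower number a stronger inhibitor. Compound 1 `CC[C@H]1CN(c2nc(N)c(C(N)=O)nc2Cl)CCN1C1CCN(Cc2ccc(C#N)cc2)CC1` gives 8.5 nM in this assay. Compound 2 `CC[C@H]1CN(c2nc(N)c(C(=O)NCC(C)O)nc2Cl)CCN1C1CCN(Cc2ccc(Cl)cc2)CC1` gives 0.3 nM in this assay, the lowest of the two numbers; the gap to compound 1 lies beyond the usual scatter. Within the data shown here, no single-point step between the two measured compounds exists, so the gap between compound 1 and compound 2 is taken only as what the two values show.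

Compound 3 `CC[C@H]1CN(c2nc(N)c(C(=O)NCCNS(=O)(=O)C(F)(F)F)nc2Cl)CCN1C1CCN(Cc2ccc(Cl)cc2)CC1` differs from compound 2 in one place: (((trifluoromethyl)sulfonyl)amino)methyl in place of 1-hydroxyethyl on a saturated chain carbon bound to an amide-type nitrogen. Nothing measured in the series bears on this replacement, so the expectation rests on compound 2 alone. The step from compound 2 to compound 3 in this assay is expected to be a 2.7-fold higher number from compound 2 to compound 3 (0.43 log units; beyond the scatter), small and toward a higher number. For compound 3 the estimate in this assay is 0.8 nM, within a range from 0.2 nM to 4 nM.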

Compound 3, half-maximal inhibitory concentration: 0.9 nM
For compound 3 the middle estimate is 1.1-fold (0.05 log units) below the measured one; measured number inside the range.
By their numbers in this assay, from the lowest: compound 2; then compound 3; then compound 1.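

Among these compounds, replacing 1-hydroxyethyl with (((trifluoromethyl)sulfonyl)amino)methyl on a saturated chain carbon bound to an amide-type nitrogen gives a 3.0-fold higher number from compound 2 to compound 3 (0.48 log units; beyond the scatter) in this assay, the first single-place reading at this position. The entering group has 9 heavy atoms against 3 for the group it replaces, yet the step is only modest, and compound 3 still reads 0.9 nM; this position therefore accepts a much larger group at the cost of a small rise in the number. Nothing measured on these compounds explains the size of this step.

As far as these compounds go, the trifluoromethyl, sulfonyl and amino parts enter together, and which of them carries the step stays open. An amine or a carboxylic acid on the same chain, or methylsulfonyl in place of the trifluoromethylsulfonyl, would bear on that question.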